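The source may hold more compounds than are shown below. What is called first, only, known or untested is meant among the compounds shown, and "the series" means these compounds.

In an ADME assay on liver (Rattus norvegicus, strain Wistar) for metabolic stability, read by LC-MS, using microsomes and NADPH, with a stated time of 15 min, tested at 1 uM (a lower number here means slower removal, a higher number faster removal of the compound), compound 1 (`C[C@@H]1CN(Cc2ccccc2)c2cncc(F)c2[C@H](C)N1C(=O)Nc1cccnc1`) gives 500 mL.min-1.g-1 and compound 2 (`COc1ccc(CNC(=O)N2[C@H](C)CN(CCC(C)C)c3cnccc3[C@@H]2C)cc1`) gives 885 mL.min-1.g-1. These two numbers lie within the usual scatter of each other, so compound 2 cannot be separated from compound 1. Compound 3 (`COc1ccc(CNC(=O)N2[C@H](C)CN(Cc3ccc(C(F)(F)F)o3)c3cnccc3[C@@H]2C)cc1`) carries 5-(trifluoromethyl)furan-2-yl in place of isobutyl on a saturated chain carbon bound to a nitrogen on an aromatic ring in a ring. Within the data shown here, no measured step covers this change, so no shift beyond the scatter is expected in this assay. The expected change is a 1.4-fold lower number from compound 2 to compound 3 (0.13 log units; within the scatter). For compound 3 the estimated value is 650 mL.min-1.g-1, with an expected range of 280 mL.min-1.g-1 to 1400 mL.min-1.g-1.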

Compound 3, intrinsic clearance in microsomes: 447 mL.min-1.g-1
Estimate against measurement, compound 3: 1.5-fold (0.16 log units) above; low and high end bracket the measured number.
By their numbers in this assay, from the lowest: compounds 3, 1 and 2 (each within the scatter of the next).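

In this assay placing 5-(trifluoromethyl)furan-2-yl for isobutyl on a saturated chain carbon bound to a nitrogen on an aromatic ring in a ring gives a 2.0-fold lower number from compound 2 to compound 3 (0.30 log units; within the scatter) and so no separable shift. This position therefore takes a five-membered aromatic ring bearing trifluoromethyl, with one hydrogen-bond acceptor where isobutyl has none, and the number stays within the scatter. Nothing shown bears on the reason for this result. On these data alone, whether an amine, a carboxylic acid or a longer chain at this place would move the number beyond the scatter remains open.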